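This account rests on a few compounds, and the source may have more. Where it says the series, first, only, none or still open, it means among the compounds named here.

Measured so far in a functional assay on the whole organism with Mus musculus as the target; on this read-out higher numbers stand for an effect only at larger amounts of compound and lower numbers for an effect already at smaller amounts:

- Compound 1 `CN(C)C(=O)Cn1c(-c2ccc(Cl)cc2)nc2cccnc21`: 4.1 mg/kg
- Compound 2 `CN1CCN(C(=O)Cn2c(-c3ccc(Cl)cc3)nc3cccnc32)CC1`: 100 mg/kg

Of these two numbers, compound 2 stands highest, so it needs the larger dose for its effect. Compound 3 `CC(=O)N1CCN(C(=O)Cn2c(-c3ccc(Cl)cc3)nc3cccnc32)CC1` differs from compound 2 in one place: acetyl in place of methyl on an amine nitrogen in a ring.

Going by the values given here, no measured step tests this exchange directly. Among the compounds with values here, the only step that bears on it is a 24-fold higher number from compound 1 to compound 2 (1.39 log units; beyond the scatter), a large change beyond the scatter, made where 4-methylpiperazin-1-yl replaced dimethylamino on a carbonyl carbon. It shows that this part of the molecule can move the number strongly. With compound 2 at 100 mg/kg, a moderate move toward a lower number in this assay is expected, though with wide uncertainty. The expected change is a 2.5-fold lower number from compound 2 to compound 3 (0.40 log units; beyond the scatter). Compound 3 is estimated at 40 mg/kg, with an expected range of 10 mg/kg to 150 mg/kg.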

Compound 3, dose for half-maximal effect: 100 mg/kg
Beside the measured number, compound 3's estimate is 2.5-fold (0.40 log units) below it; the range from low to high includes it.
By their numbers in this assay, from the lowest: compound 1; then compounds 2 and 3 (each within the scatter of the next).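

In this assay, the change on the amine nitrogen in the ring gives no change at the digits printed from compound 2 to compound 3 (within the scatter), so acetyl and methyl cannot be told apart at this position, even though acetyl brings more heavy atoms and a hydrogen-bond acceptor. With the second piperazine, the comparison with the dimethylamino amide gives a 24-fold higher number from compound 1 to compound 3 (1.39 log units; beyond the scatter), which matches the step seen earlier with 4-methylpiperazin-1-yl, a 24-fold higher number from compound 1 to compound 2 (1.39 log units; beyond the scatter). The large step therefore holds for both of these piperazine groups, and the choice between methyl and acetyl does not alter it. Nothing available bears on the cause of this result.

As far as these compounds go, it remains open whether any group on this nitrogen can bring the number down, such as a plain hydrogen, a longer chain or a carboxylic acid. A morpholine ring in place of the piperazine is also untested among the compounds shown.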